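Fluoro for cyano on the aminopyridine amide

A few compounds are considered here, and "the series" means these few. Any claim that something is new, unique, unknown or untested is made for them only; others in the source may bear on it.

Compound 1 `Cc1c(F)cccc1C(=O)Nc1ccccn1`: 25 ug/mL
Compound 2 `Cc1ccccc1C(=O)Nc1ccc(C#N)cn1`: 6.3 ug/mL
Compound 3 `Cc1ccnc(NC(=O)c2cccc(F)c2C)c1`: 25 ug/mL

In a physicochemical assay for solubility, read by nephelometry, measured as kinetic solubility, at pH 6.5, tested at 10 mg/mL (a higher number here means a more soluble compound, a lower number a less soluble compound), compound 2 gives the lowest of the three numbers, below compound 1 and compound 3, both gaps beyond the scatter. Compound 4 `Cc1ccccc1C(=O)Nc1ccc(F)cn1` differs from compound 2 in one place: fluoro in place of cyano on an aromatic carbon. For the measured compounds named here, no measured step exchanges cyano for fluoro. Going by the values given here, the only measured step, no change at the digits printed from compound 1 to compound 3 (within the scatter), concerns a different change and offers no direct guide. Compound 1 carries fluoro and shows the higher value, but that fluoro sits on the other ring, so the comparison is loose. Compound 4 is therefore expected to move modestly upward, by a 2.1-fold higher number from compound 2 to compound 4 (0.31 log units; beyond the scatter), with the estimate 13 ug/mL and range 5 ug/mL to 32 ug/mL.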

Compound 4, solubility: 25 ug/mL
For compound 4 the middle estimate is 1.9-fold (0.28 log units) below the measured one, and the stated range covers the measured number.
By their numbers in this assay, from the lowest: compound 2; then compounds 1, 3 and 4 (each within the scatter of the next).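

The earlier compounds shown here held no step at this position, two atoms from the ring nitrogen and para to a large group. In this assay, the exchange of cyano for fluoro now gives a direct reading there: a 4.0-fold higher number from compound 2 to compound 4 (0.60 log units; beyond the scatter). Nothing available explains this difference. 

On these data alone, this rests on a single pair, so whether the exchange gives a similar step on another core remains open. As far as these compounds go, how an amine or a carboxylic acid at this position would read also remains unknown.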